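The source may hold more compounds than are shown below. What is called first, only, known or untested is meant among the compounds shown, and "the series" means these compounds.

Series notes on the shared core of compound 3 `Cc1nn(-c2ccccc2C(C)C)c2c1[C@@H](c1ccc(Oc3ccccc3)cc1)S[C@@H](C)C(=O)N2`. Going by the values given here, in an assay on isolated protein for agonist activity at Bile acid receptor (Homo sapiens), read by AlphaScreen, with a stated time of 30 min (a lower number here means that less compound is needed, a higher number that more compound is needed for the effect), compound 3 gives 1900 nM, the only numerical value shown for the series. Compound 1 `Cc1ccccc1-n1nc(C)c2c1NC(=O)[C@H](C)S[C@@H]2c1ccc(Oc2cccc(C(=O)O)c2)cc1` and compound 2 `Cc1ccccc1-n1nc(C)c2c1NC(=O)[C@H](C)S[C@@H]2c1ccc(-c2ccc(C(=O)O)cc2)cc1` carry a carboxylic acid on the distal ring. In this assay, among the compounds with values here, compound 1 is recorded as "not active" (no number reported) and compound 2 as "not active" (no number reported), without a number; they set no step that can be measured against compound 3.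

Compound 4 `Cc1ccccc1-n1nc(C)c2c1NC(=O)[C@H](C)S[C@@H]2c1ccc(Oc2ccccc2)cc1` is the next entry. It differs from compound 3 by methyl in place of isopropyl on an aromatic carbon. From the compounds shown here alone, compound 1 and compound 2 also carry the 2-methylphenyl, but each with the acid as a second difference, so they offer no clean comparison and the effect of the methyl alone is unknown. Within the data shown here, no step isolates this change.

Expectation: a move from the isopropyl to the methyl is taken to cost some potency, so compound 4 is expected to need more compound than compound 3, with the step from compound 3 to compound 4 estimated as a 2.4-fold higher number from compound 3 to compound 4 (0.37 log units; beyond the scatter), modestly beyond the scatter. Compound 4 is therefore estimated at 4500 nM in this assay, within a range of 1500 nM to 15000 nM, with a real chance that only a limit is reported.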

Compound 4, half-maximal effective concentration: 1300 nM
Compound 4: the middle estimate sits 3.5-fold (0.54 log units) above what was measured; measured number below the stated range.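

In this assay, the exchange of 2-isopropylphenyl for 2-methylphenyl gives a 1.5-fold lower number from compound 3 to compound 4 (0.16 log units; within the scatter), so the two groups cannot be told apart at this place, and the removal of two carbons from the group ortho to a large group leaves a measurable value in place. Going by these compounds alone, compound 4 also gives the first number for the series with the 2-methylphenyl, so that group alone does not account for the "not active" record of compound 1, which differs from compound 4 by the carboxylic acid on the distal ring, although no size can be put on that difference. No measurement on hand explains why the exchange leaves the value within the scatter.

The compounds shown leave open whether this tolerance extends to groups outside the methyl and isopropyl pair, such as ethyl, tert-butyl, methoxy or chlorine, or to a plain phenyl with only hydrogen at this place. They also leave open whether a distal ring carrying an amine or an ester, rather than a carboxylic acid, would keep a numerical value in this assay.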